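The source may report more compounds than this note shows. Statements on the series, on what has been measured and on what is new or still open speak of the compounds shown alone.

In a physicochemical assay for lipophilicity, measured as octanol-water partition (a higher number here means a more lipophilic compound, a lower number a more polar compound), compound 2 `CC1=C(C(=O)OCc2ccccn2)C(c2ccc([N+](=O)[O-])cc2)C2=C(CCCC2=O)N1` stands highest of the three measured compounds at 1.88, ahead of compound 3 `CC1=C(C(=O)OCc2cccnc2)C(c2ccc([N+](=O)[O-])cc2)C2=C(CCCC2=O)N1` at 1.51 and compound 1 `CC1=C(C(=O)OCc2cccnc2)C(c2ccco2)C2=C(CCCC2=O)N1` at 1.03. Compound 4 `CC1=C(C(=O)OCc2ccccn2)C(c2cccc([N+](=O)[O-])c2)C2=C(CCCC2=O)N1` differs from compound 2 in one place, with 3-nitrophenyl in place of 4-nitrophenyl on a saturated ring carbon. Within the data shown here, no measured step makes this exact exchange. The closest evidence is a number 0.48 log units higher from compound 1 to compound 3 (beyond the scatter), a whole group exchanged on that carbon, and a number 0.37 log units lower from compound 2 to compound 3 (beyond the scatter), a swap of one isomeric group for another elsewhere. Both are modest, and the second warns that such swaps can register. Still, the expected step is a number 0.03 log units lower from compound 2 to compound 4 (within the scatter), which means no change beyond the scatter in this assay. For compound 4 the estimated value is 1.85, with an expected range of 1.5 to 2.2.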

Compound 4, partition coefficient: 1.88
Beside the measured number, compound 4's estimate is 0.03 log units below it; the measured number falls inside the stated range.
By their numbers in this assay, from the lowest: compound 1; then compound 3; then compounds 2 and 4 (each within the scatter of the next).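

In this assay, 3-nitrophenyl in place of 4-nitrophenyl on this saturated ring carbon gives no change at the digits printed from compound 2 to compound 4 (within the scatter). The two earlier exchanges, furan-2-yl for 4-nitrophenyl on this carbon and pyridin-3-yl for pyridin-2-yl on the chain carbon, both registered, whereas this one does not. Nothing available explains why the two nitrophenyl groups read alike. Still open, as far as these compounds go, is how a phenyl ring carrying an amine or a carboxylic acid instead of the nitro group would read on this carbon. From the compounds shown here alone, whether 3-nitrophenyl reads the same alongside pyridin-3-yl is also open.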